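From methoxy to dimethylamino on the shared core

The source may hold more compounds than are shown below. What is called first, only, known or untested is meant among the compounds shown, and "the series" means these compounds.

- Compound 1 `c1ccc(-c2ccc(-c3ccc(-c4nc5ccccc5[nH]4)cc3)cc2)cc1` gives 100000 nM 
- Compound 2 `Fc1ccc(-c2ccc(-c3ccc(-c4nc5ccccc5[nH]4)cc3)cc2)cc1` gives 39300 nM 
- Compound 3 `COc1ccc(-c2ccc(-c3ccc(-c4nc5ccccc5[nH]4)cc3)cc2)cc1` gives 100000 nM 
- Compound 4 `CN(C)c1ccc(-c2ccc(-c3ccc(-c4nc5ccccc5[nH]4)cc3)cc2)cc1` is not yet measured

In a functional assay on HOP-62 cells (Homo sapiens) for inhibition, read by sulforhodamine B assay (on this read-out higher numbers stand for weaker inhibition of growth and lower numbers for stronger inhibition of growth), compound 3 stands at 100000 nM and so level with compound 1, the two sharing the highest number of the three. The next step puts dimethylamino in place of methoxy on an aromatic carbon, para to a large group (dimethylamino in place of methoxy on an aromatic carbon), and leaves the shared core as it is. Among the compounds with values here, no measured compound carries dimethylamino, so the evidence is indirect. Within the data shown here, three steps bear on it. Methoxy in place of hydrogen gave no change at the digits printed from compound 1 to compound 3 (within the scatter) and fluoro in place of hydrogen gave a 2.5-fold lower number from compound 1 to compound 2 (0.41 log units; beyond the scatter) while methoxy in place of fluoro gave a 2.5-fold higher number from compound 2 to compound 3 (0.41 log units; beyond the scatter) so no measured step is more than modest. A step of similar size at most is therefore expected in this assay, with a slightly lower number or no change beyond the scatter as the likely outcome. The estimate means an expected 1.4-fold lower number from compound 3 to compound 4 (0.15 log units; within the scatter) in this read-out. The estimate for compound 4 is 70000 nM with an expected range from 25000 nM to 100000 nM on present evidence.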

Compound 4, concentration for 50% growth inhibition: 100000 nM
Compound 4: middle estimate off by 1.4-fold (0.15 log units), on the low side; the measured number falls inside the stated range.
By their numbers in this assay, from the lowest: compound 2; then compounds 1, 3 and 4 (each within the scatter of the next).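

In this assay, the step to dimethylamino gives no change at the digits printed from compound 3 to compound 4 (within the scatter) and, against the unsubstituted parent, no change at the digits printed from compound 1 to compound 4 (within the scatter) at this site, on an aromatic carbon, para to a large group. Dimethylamino therefore falls with methoxy and hydrogen rather than with fluoro, as shown by a 2.5-fold higher number from compound 2 to compound 4 (0.41 log units; beyond the scatter) in the same series, so compound 2 is now the only one of the four set apart beyond the scatter. No available evidence bears on why fluoro alone separates from the other groups.

As far as these compounds go, whether chloro or another halogen would share the lower number of compound 2 remains open. Also open, from the compounds shown here alone, is whether a carboxylic acid, a nitrile or a longer chain at this site would move the number at all.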